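Swapping the aryl ketone partner on a chalcone-pyrazole scaffold

The source may hold more compounds than are shown below. What is called first, only, known or untested is meant among the compounds shown, and "the series" means these compounds.

Measured so far:
compound 1, `COc1ccc(-c2cc(/C=C/C(=O)c3ccc(N)cc3)[nH]n2)cc1`: 1180 nM
compound 2, `COc1cc(-c2cc(/C=C/C(=O)c3ccc(Cl)c(Cl)c3)[nH]n2)cc(OC)c1OC`: 5730 nM

Of the compounds shown here, two have been tested in a functional assay on UO-31 cells (Homo sapiens) for inhibition, read by sulforhodamine B assay, with a stated time of 48 h; on this read-out lower numbers stand for stronger inhibition of growth and higher numbers for weaker inhibition of growth. Compound 1 gives 1180 nM, while compound 2 gives 5730 nM. Compound 2 therefore carries the higher of the two numbers, and the gap between compound 2 and compound 1 lies beyond the usual scatter of this assay. The two compounds differ in more than one place, so no single change can be tied to that gap.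

Compound 3, `COc1ccc(C(=O)/C=C/c2cc(-c3cc(OC)c(OC)c(OC)c3)n[nH]2)cc1`, is the next compound to be measured. It differs from compound 2 in one place: 4-methoxyphenyl in place of 3,4-dichlorophenyl on a carbonyl carbon. The rest of the shared core is kept unchanged.

Going by the values given here, since no step between measured compounds isolates this change, the expectation for compound 3 rests on the general picture only. Compound 3 is expected to show a modest step toward a lower number in this assay, with a fair chance that the step stays within the scatter, so that the estimated step is a 1.9-fold lower number from compound 2 to compound 3 (0.28 log units; within the scatter). On that basis compound 3 is estimated at 3000 nM, with a range from 1000 nM to 9000 nM.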

Compound 3, concentration for 50% growth inhibition: 1450 nM
Estimate against measurement, compound 3: 2.1-fold (0.32 log units) above; the measured number falls inside the stated range.
By their numbers in this assay, from the lowest: compounds 1 and 3 (each within the scatter of the next); then compound 2.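

In this assay, going by these compounds alone, 4-methoxyphenyl in place of 3,4-dichlorophenyl on a carbonyl carbon gives a 4.0-fold lower number from compound 2 to compound 3 (0.60 log units; beyond the scatter), and this is the first step that can be tied to one change. The gap between the first two compounds could not be assigned to any single place, whereas this pair shows that the aryl group on the carbonyl carbon can, with the rest of the shared core unchanged, move the number beyond the scatter. Nothing available explains why this swap lowers the number.

With only these two groups compared at this place, the step cannot be divided between gaining the methoxy group and losing the two chlorine atoms. From the compounds shown here alone, it remains open whether a 4-chlorophenyl or a 4-hydroxyphenyl on the same carbonyl carbon would give a number closer to that of compound 2 or that of compound 3, and whether the step would carry over to a core other than that of compound 2.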